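Tetrahydroisoquinoline Amides Tested Against Thyroid Hormone Receptor Alpha

The source may hold more compounds than are shown below. What is called first, only, known or untested is meant among the compounds shown, and "the series" means these compounds.

Compound 1 `CC(C)N(C(=O)CCNC(=O)c1ccc(S(C)(=O)=O)c([N+](=O)[O-])c1)C(C)C` and compound 3 `CS(=O)(=O)c1ccc(C(=O)NCCC(=O)N2CCc3ccccc3C2)cc1[N+](=O)[O-]` share a core in which a chain links the substituted benzamide to a second carbonyl; compound 2 `CC(C)N(C(=O)C1CCN(C(=O)c2ccc(S(C)(=O)=O)c([N+](=O)[O-])c2)CC1)C(C)C` and compound 4 `CS(=O)(=O)c1ccc(C(=O)N2CCC(C(=O)N3CCc4ccccc4C3)CC2)cc1[N+](=O)[O-]` share a different core. The difference between the two cores is not broken down here.

In an assay on isolated protein for inhibition of thyroid hormone receptor alpha (Homo sapiens), read by fluorescence polarization (on this read-out lower numbers stand for stronger inhibition and higher numbers for weaker inhibition), compound 1 gives > 60000 nM, which is a limit of the assay rather than a number. In this assay compound 2 gives > 60000 nM, again a limit. Compound 3 gives > 60000 nM in this assay, also a limit. The change from compound 1 to compound 3 is 1,2,3,4-tetrahydroisoquinolin-2-yl in place of diisopropylamino on a carbonyl carbon, and the step that the two limits leave unreadable from compound 1 to compound 3 cannot be sized because of the limit of > 60000 nM in this assay, at which 3 of the 3 values shown sit.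

Compound 4 differs from compound 2 by 1,2,3,4-tetrahydroisoquinolin-2-yl in place of diisopropylamino on a carbonyl carbon. The surroundings of the place are not identical: in compound 1 the carbonyl carbon's other neighbour is a saturated chain carbon, whereas in compound 2 it is a saturated ring carbon, so the change is the same kind of change, not the same one. The expectation for compound 4 rests on the unreadable step that the two limits leave unreadable from compound 1 to compound 3 and on the three limits in this assay, which give no sign that this change brings activity within range. Compound 4 is therefore expected to give about 60000 nM in this assay, between 25000 nM and 200000 nM. The estimated step from compound 2 to compound 4 in this assay is a number no higher from compound 2 to compound 4 (the limit leaves the size open), meaning no change that can be read.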

Compound 4, half-maximal inhibitory concentration: > 60000 nM
Compound 4 gave a limit, no number (the forecaster's own chance of this, stated with the estimate: 85%); the middle value lies on the limit itself.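

In this assay compound 4 gives > 60000 nM which is a limit of the assay and not a number. The change from compound 2 to compound 4 therefore cannot be sized, and no new step can be read: the limit of > 60000 nM in this assay, at which 4 of the 4 values shown sit.

The compounds shown leave open whether diisopropylamino and 1,2,3,4-tetrahydroisoquinolin-2-yl differ at all on this target, and what would bring a value within range.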